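This account rests on a few compounds, and the source may have more. Where it says the series, first, only, none or still open, it means among the compounds named here.

Compound 1 `CCCCCc1cn([C@@H]2O[C@@H]3CO[PH](O)(O)O[C@H]3[C@H]2O)c(=O)nc1N` has only a limit in a functional assay on L1210 cells (Mus musculus) for cytotoxicity; a lower number here means a stronger inhibitor, a higher number a weaker inhibitor: in this assay compound 1 gives > 200 ug/mL, which is a limit of the assay and not a number. Compound 2 `CCCCCCc1cn([C@@H]2O[C@@H]3COP(=O)(O)O[C@H]3[C@H]2O)c(=O)nc1N` also sits at a limit; in this assay compound 2 gives > 200 ug/mL. Compound 1 stands at the limit of > 200 ug/mL in this assay, at which 2 of the 2 values shown sit, with nothing measured below it. Compound 3 `CCCc1cn([C@@H]2O[C@@H]3CO[PH](O)(O)O[C@H]3[C@H]2O)c(=O)nc1N` differs from compound 1 by hydrogen in place of ethyl on a saturated chain carbon, three bonds along the chain from an aromatic carbon. Among the compounds with values here, no step between measured compounds is available; the expected step from compound 1 to compound 3 is a number no higher from compound 1 to compound 3 (the limit leaves the size open), none beyond the scatter. Compound 3 is expected to give about 200 ug/mL, most likely again as a limit, between 100 ug/mL and 400 ug/mL.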

Compound 3, concentration for 50% inhibition: > 200 ug/mL
Compound 3: no number, only a limit (the forecaster's own chance of this, stated with the estimate: 85%); the middle value lies on the limit itself.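

No step can be read between compound 1 and compound 3, because both stand at a limit and not at a number: the limit of > 200 ug/mL in this assay, at which 3 of the 3 values shown sit. The compounds shown leave open whether pentyl to propyl changes the read-out in this assay at all.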